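Replacing 1,3-benzothiazol-5-yl in compound 3

The compounds below may be only part of what the source reports. "The series", "measured", "known", "first", "only" and "open" are said of these compounds alone.

Measured in a functional assay on MCF7 cells (Homo sapiens) for antiproliferative activity, read by CellTiter-Glo, with a stated time of 5 days; a lower number here means a stronger inhibitor, a higher number a weaker inhibitor:
- Compound 1 `O=C(O)/C=C/c1ccc(/C(=C(\c2ccccc2)C2CCC2)c2ccc3scnc3c2)cc1`: 16 nM
- Compound 2 `O=C(O)/C=C/c1ccc(/C(=C(\c2ccc(F)cc2Cl)C2CCC2)c2ccc3scnc3c2)cc1`: 3 nM
- Compound 3 `N#Cc1cc(Cl)ccc1/C(=C(\c1ccc(/C=C/C(=O)O)cc1)c1ccc2scnc2c1)C1CCC1`: 0.9 nM

Compound 3 has the lowest number of the three, with compound 2 its nearest neighbour. Compound 4 `N#Cc1cc(Cl)ccc1/C(=C(\c1ccc(/C=C/C(=O)O)cc1)c1ccc(-c2cncs2)cc1)C1CCC1` carries 4-(1,3-thiazol-5-yl)phenyl in place of 1,3-benzothiazol-5-yl on a double-bonded chain carbon bound to an aromatic carbon and a double-bonded chain carbon.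

Within the data shown here, no measured step touches this place. The steps of a 5.3-fold lower number from compound 1 to compound 2 (0.73 log units; beyond the scatter), an 18-fold lower number from compound 1 to compound 3 (1.25 log units; beyond the scatter) and a 3.3-fold lower number from compound 2 to compound 3 (0.52 log units; beyond the scatter) all change the group on a double-bonded chain carbon bound to a double-bonded chain carbon and a saturated ring carbon. Among the measured compounds shown here, they show only that one group can matter, so the size here is uncertain. With compound 3 at 0.9 nM, a modest move to a higher number is expected in this assay. The expected change is a 3.3-fold higher number from compound 3 to compound 4 (0.52 log units; beyond the scatter). The estimate for compound 4 is 3 nM, within an expected range of 0.7 nM to 15 nM.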

Compound 4, half-maximal inhibitory concentration: 4.3 nM
Compound 4: middle estimate off by 1.4-fold (0.16 log units), on the low side; measured number inside the range.
By their numbers in this assay, from the lowest: compound 3; then compounds 2 and 4 (each within the scatter of the next); then compound 1.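

In this assay, among these compounds, 4-(1,3-thiazol-5-yl)phenyl in place of 1,3-benzothiazol-5-yl gives a 4.8-fold higher number from compound 3 to compound 4 (0.68 log units; beyond the scatter), the first evidence that this place, too, affects the number beyond the scatter. The entering group has 11 heavy atoms against 9 for the one it replaces, yet compound 4 still reads 4.3 nM. No measurement shown explains this step. On these data alone, what a pyridine or an amine would give at this place remains open. So does whether the step keeps its size with the other groups carried by compound 1 and compound 2.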